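Ethyl to ethoxy on the phenyltriazole arm of a spirooxindole series

A few compounds are considered here, and "the series" means these few. Any claim that something is new, unique, unknown or untested is made for them only; others in the source may bear on it.

Measured compounds:
compound 1, `N#CC1=C(N)Oc2c(c3nc4ccccc4nc3c3ccccc23)C12C(=O)N(Cc1cnnn1-c1ccc([N+](=O)[O-])cc1)c1ccccc12`: > 50000 nM
compound 2, `N#CC1=C(N)Oc2c(c3nc4ccccc4nc3c3ccccc23)C12C(=O)N(Cc1cnnn1-c1ccc(Cl)c(Cl)c1)c1ccccc12`: > 50000 nM
compound 3, `CCc1ccccc1-n1nncc1CN1C(=O)C2(C(C#N)=C(N)Oc3c(N)cc4nc5ccccc5nc4c32)c2ccccc21`: 24600 nM

In a functional assay on A549 cells (Homo sapiens) for antiproliferative activity, read by MTT assay, with a stated time of 48 h (on this read-out higher numbers stand for weaker inhibition and lower numbers for stronger inhibition), compound 1 gives only a limit, > 50000 nM. Compound 2 likewise gives only a limit, > 50000 nM. The step that the two limits leave unreadable from compound 1 to compound 2 therefore cannot be read, because both values sit at the limit of > 50000 nM in this assay, at which 2 of the 3 values shown sit. For the measured compounds named here, compound 3 is the sole compound with a number in this assay, 24600 nM, and that number stands at the weak end of what this assay reports.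

Compound 4, `CCOc1ccccc1-n1nncc1CN1C(=O)C2(C(C#N)=C(N)Oc3c(N)cc4nc5ccccc5nc4c32)c2ccccc21`, differs from compound 3 by ethoxy in place of ethyl on an aromatic carbon. Going by the values given here, no measured step touches this position: the single measured step is the unreadable one from compound 1 to compound 2, which concerns a different ring and is bounded by the limit at both ends. The change itself is small, one heavy atom more and one acceptor gained, so there is no basis in the shown data for expecting a step beyond the scatter in this assay, in either direction.

Compound 4 is therefore estimated to show a step of a 1.1-fold higher number from compound 3 to compound 4 (0.06 log units; within the scatter), i.e. no movement beyond the scatter. For compound 4 a value of 28000 nM is expected, within a range from 11000 nM to 70000 nM, with a real chance that this assay returns only a limit.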

Compound 4, half-maximal inhibitory concentration: > 50000 nM
Compound 4: only a limit was reported; the forecaster's own chance of this, stated with the estimate: 35%; middle value at least 1.7-fold (0.25 log units) from the limit.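

In this assay, for the compounds shown here, ethoxy in place of ethyl on an aromatic carbon, ortho to a large group, gives an at least 2.0-fold higher number from compound 3 to compound 4 (0.30 log units; that floor lies within the scatter), the first step that can be read at all. Compound 4 gives > 50000 nM, which is a limit of the assay and not a number. This position therefore gives no sign that ethoxy improves on ethyl, although the floor of the step does not establish a real loss, and compound 3 remains the only compound with a number, with the rest of the set sitting at one ceiling: the limit of > 50000 nM in this assay, at which 3 of the 4 values shown sit.

The compounds shown leave open the true size of this step, which has a floor and no upper bound, and whether the 2-ethoxyphenyl arm differs from the 2-ethylphenyl arm by more than the scatter. They also leave open how a methoxy group, a longer chain such as propyl, an amine or a carboxylic acid at this same place would read against compound 3, and whether any of these would move the value at all.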